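A few compounds are considered here, and "the series" means these few. Any claim that something is new, unique, unknown or untested is made for them only; others in the source may bear on it.

In a functional assay on OVCAR-3 cells (Homo sapiens) for antiproliferative activity, read by MTT assay, with a stated time of 24 h (a higher number here means a weaker inhibitor, a lower number a stronger inhibitor), compound 1 `O=c1[nH]cc(S(=O)(=O)Nc2ccccc2-c2cn(-c3ccc(Cl)cc3)nn2)c(=O)[nH]1` gives 1750 nM, compound 2 `Cc1ccccc1-n1cc(-c2cccc(NS(=O)(=O)c3c[nH]c(=O)[nH]c3=O)c2)nn1` gives 6230 nM, and compound 3 `Cc1ccc(-n2cc(-c3ccc(NS(=O)(=O)c4c[nH]c(=O)[nH]c4=O)cc3)nn2)cc1` gives 5630 nM. Compound 3 thus stands second highest of the three numbers: against compound 2 it lies within the scatter, while compound 1 sits beyond the scatter with the lower number. Compound 4 `O=c1[nH]cc(S(=O)(=O)Nc2ccc(-c3cn(-c4cccc(Cl)c4)nn3)cc2)c(=O)[nH]1` has not yet been measured in this assay. It differs from compound 3 by 3-chlorophenyl in place of 4-methylphenyl on an aromatic nitrogen. Without a measured step of this kind, only a small step is expected, a 1.4-fold lower number from compound 3 to compound 4 (0.15 log units; within the scatter), not clearly beyond the scatter, leaning if anything toward a lower number. Compound 4 is therefore estimated at 4000 nM in this assay, with a range from 1500 nM to 10000 nM.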

Compound 4, half-maximal inhibitory concentration: 2750 nM
Estimate against measurement, compound 4: 1.5-fold (0.16 log units) above, within the range that was stated.
By their numbers in this assay, from the lowest: compounds 1 and 4 (each within the scatter of the next); then compounds 3 and 2 (each within the scatter of the next).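

In this assay, going by these compounds alone, the exchange of 4-methylphenyl for 3-chlorophenyl gives a 2.0-fold lower number from compound 3 to compound 4 (0.31 log units; beyond the scatter) and is the first measured step at this aromatic nitrogen. The step is modest, but it shows that the number can move at this position even though the two groups have the same heavy-atom count and ring type. No measurement given here accounts for the step. The step changes both the substituent and its place on the phenyl ring, and the two cannot be separated with 3-methylphenyl or 4-chlorophenyl absent from this series. Going by these compounds, how an amine or a carboxylic acid on that phenyl ring would read also remains open.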